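Ester to oxadiazole swap on the shared core: cytotoxicity outlook

A few compounds are considered here, and "the series" means these few. Any claim that something is new, unique, unknown or untested is made for them only; others in the source may bear on it.

Compound 3 `CCOC(=O)c1cnc2ccc(-c3ccc(N)cc3)cc2c1` carries an ethoxycarbonyl on the shared core and a para-aminophenyl arm. In a functional assay on RD cells (Homo sapiens) for inhibition, read by luminescence and ATP content, with a stated time of 72 h (on this read-out lower numbers stand for higher toxicity in this test and higher numbers for lower toxicity in this test), compound 3 gives > 7400 nM, which is a limit of the assay and not a number. The two neighbours are no more informative: compound 1 `CCCc1ccc(-c2ccc3ncc(C(=O)OCC)cc3c2)cc1` gives > 7400 nM in this assay, again a limit. Compound 2 `CCCCc1ccc(-c2ccc3ncc(C(=O)OCC)cc3c2)cc1` gives > 7400 nM, also a limit. Hence compound 3 stands at the limit of > 7400 nM in this assay, at which 3 of the 3 values shown sit, together with the whole series. The measured steps a step that the two limits leave unreadable from compound 1 to compound 2, a step that the two limits leave unreadable from compound 1 to compound 3 and a step that the two limits leave unreadable from compound 2 to compound 3 all remain unreadable, and none of them touches the position varied here. Compound 4 `Cc1nc(-c2cnc3ccc(-c4ccc(N)cc4)cc3c2)no1` differs from compound 3 by 5-methyl-1,2,4-oxadiazol-3-yl in place of ethoxycarbonyl on an aromatic carbon. Within the data shown here, no measured step bears on this exchange, so the expectation rests only on the series sitting uniformly at the limit. Compound 4 is expected to show a step that the limit leaves unreadable from compound 3 to compound 4, that is, no step beyond the scatter. The estimate for compound 4 in this assay is 10000 nM, within 3000 nM to 40000 nM, most likely reported as a limit again.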

Compound 4, half-maximal cytotoxic concentration: > 2500 nM
Compound 4 ended at the assay's limit (the forecaster's own chance of this, stated with the estimate: 80%); the middle value is on the limit's open side.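

Compound 3 and compound 4 both stand at limits and not numbers in this assay, and no step can be read between them. The compounds shown leave open where any of them reaches a half-maximal cytotoxic concentration, and whether the 5-methyl-1,2,4-oxadiazol-3-yl exchange changes it.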